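From methyl to isopropyl: an estimate for compound 4

The source may hold more compounds than are shown below. What is called first, only, known or untested is meant among the compounds shown, and "the series" means these compounds.

In a physicochemical assay for solubility, read by spectrophotometry, in phosphate buffer, with a stated time of 18 h, at pH 7.4 (a higher number here means a more soluble compound, a lower number a less soluble compound), compound 1 `CCc1ccc(-c2nc3c(c(C)nn3-c3ccccc3)c(-c3ccccc3)c2C#N)cc1` gives 47000 nM and compound 2 `CCc1ccc(-c2nc3c(c(C)nn3-c3ccccc3)c(-c3ccccc3C(=O)OC)c2C#N)cc1` gives 17000 nM. Compound 3 `Cc1ccc(-c2nc3c(c(C)nn3-c3ccccc3)c(-c3ccccc3O)c2C#N)cc1` gives 26000 nM (within the scatter of both of the others). Compound 4 `Cc1nn(-c2ccccc2)c2nc(-c3ccc(C(C)C)cc3)c(C#N)c(-c3ccccc3O)c12` differs from compound 3 by isopropyl in place of methyl on an aromatic carbon. For the measured compounds named here, the only measured step is a 2.8-fold lower number from compound 1 to compound 2 (0.44 log units; beyond the scatter) (a modest one, for methoxycarbonyl in place of hydrogen). Going by the values given here, that is a different change, so it bears only loosely, and no measured pair tests this swap. The expected result is a small step that stays within the scatter (a 1.4-fold lower number from compound 3 to compound 4 (0.14 log units; within the scatter)). For compound 4 the estimated value is 19000 nM (expected range 8000 nM to 38000 nM).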

Compound 4, solubility: 9800 nM
Compound 4: the middle estimate sits 1.9-fold (0.29 log units) above what was measured; measured number inside the range.
By their numbers in this assay, from the lowest: compounds 4, 2, 3 and 1 (each within the scatter of the next, the first and the last beyond it).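

In this assay, for the compounds shown here, the change from 4-methylphenyl to 4-isopropylphenyl gives a 2.7-fold lower number from compound 3 to compound 4 (0.42 log units; beyond the scatter) and is the first measured change at this place, on an aromatic carbon para to a large group. It shows that even a small alkyl swap here can move the number beyond the scatter. No measured evidence accounts for this step.

A single step sets no trend. Going by these compounds, whether tert-butyl would continue the fall, or an amine or a carboxylic acid at this place would reverse it, stays open.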